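Pyridin-3-yl in place of phenyl in compound 1

A few compounds are considered here, and "the series" means these few. Any claim that something is new, unique, unknown or untested is made for them only; others in the source may bear on it.

Within the data shown here, in an in vitro ADME assay on microsomes from liver (Mus musculus) for metabolic stability, tested at 5 uM (on this read-out lower numbers stand for a shorter-lived compound and higher numbers for a longer-lived compound), compound 1 `C=CC(=O)NCc1coc(-c2c(N)ncnc2Nc2ccc(Oc3ccccc3)c(Cl)c2)n1` gives 0.8 h, the only exact number so far. Compound 2 `C=CC(=O)NCc1coc(-c2c(N)ncnc2Nc2ccc(Oc3ccc(F)cc3)c(Cl)c2)n1` reads > 1.66 h, which is a limit of the assay. Compound 3 `C=CC(=O)NCc1coc(-c2c(N)ncnc2Nc2ccc(Oc3cccnc3)c(Cl)c2)n1` carries pyridin-3-yl in place of phenyl on an oxygen on an aromatic ring. Among the measured compounds shown here, only one measured step bears on this change: an at least 2.0-fold higher number from compound 1 to compound 2 (0.31 log units; beyond the scatter), with fluoro in place of hydrogen on an aromatic carbon. It is a different change and so only a weak guide. A small upward move that stays within the scatter is expected, a 1.5-fold higher number from compound 1 to compound 3 (0.18 log units; within the scatter). Compound 3 is estimated at 1.2 h, with an expected range of 0.6 h to 2.4 h.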

Compound 3, half-life: 0.3 h
Beside the measured number, compound 3's estimate is 4.0-fold (0.60 log units) above it; measured number below the stated range.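

In this assay, among these compounds, the outer ring on this oxygen now shows that the read-out can fall as well as rise: a 2.7-fold lower number from compound 1 to compound 3 (0.43 log units; beyond the scatter) is a step downward, where the only earlier step went upward. Set against the 4-fluorophenyl group, the gap is wider, at an at least 5.5-fold lower number from compound 2 to compound 3 (0.74 log units; beyond the scatter). The value of compound 2 is a limit and not a number, so this second step gives only a minimum size: the limit of > 1.66 h in this assay, at which 1 of the 3 values shown sits.

From the compounds shown here alone, whether pyridin-2-yl, pyridin-4-yl or a fluoro-substituted pyridin-3-yl on the same oxygen would read like compound 3 remains open.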